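The source may hold more compounds than are shown below. What is called first, only, known or untested is meant among the compounds shown, and "the series" means these compounds.

Measured so far in an ADME assay on microsomes from liver (Mus musculus) for metabolic stability, read by LC-MS, using NADPH, with a stated time of 30 min; on this read-out lower numbers stand for a less stable compound and higher numbers for a more stable compound:

- compound 1 `CC(C)(C)c1sc2ncnc(Oc3ccccc3F)c2c1-c1ccccc1` gives 14%
- compound 2 `CC(C)(C)c1sc2ncnc(Oc3ccccc3F)c2c1-c1ccc(F)cc1` gives 7%
- compound 3 `CC(C)(C)c1sc2ncnc(Oc3ccccc3OC(F)(F)F)c2c1-c1ccc(F)cc1` gives 28%

Compound 3 stands highest of these three. The next compound to be tested, compound 4 `CC(C)(C)c1sc2ncnc(Oc3ccccc3OC(F)(F)F)c2c1-c1ccc(Cl)c(Cl)c1`, differs from it in one place: 3,4-dichlorophenyl in place of 4-fluorophenyl on an aromatic carbon. The measured step closest to this one touches the same aromatic ring, and it is small: a number 7 percentage points lower from compound 1 to compound 2 (within the scatter). The larger step, a number 21 percentage points higher from compound 2 to compound 3 (beyond the scatter), was a trifluoromethoxy for fluoro swap elsewhere in the molecule, so it says little about this change. No shift beyond the scatter is therefore expected in this assay, and the estimated change is a number 4 percentage points lower from compound 3 to compound 4 (within the scatter). For compound 4 the expected value is 24%, with an estimated range from 10% to 42%.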

Compound 4, percent of the compound remaining: 58%
Compound 4: the middle estimate sits 34 percentage points below what was measured; measured number above the stated range.
By their numbers in this assay, from the lowest: compounds 2 and 1 (each within the scatter of the next); then compound 3; then compound 4.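

In this assay, 3,4-dichlorophenyl in place of 4-fluorophenyl gives a number 30 percentage points higher from compound 3 to compound 4 (beyond the scatter). Adding a single fluoro on this same ring had given only a number 7 percentage points lower from compound 1 to compound 2 (within the scatter), so this position can move the read-out beyond the scatter when the ring's substituents change. No measurement shown here accounts for the rise. On these data alone, it remains open whether the two chlorines are both needed, or whether one chlorine alone would give a similar number. As far as these compounds go, a methyl, a nitrile or an amine on this ring is equally open.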